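Defining Both Stereocentres of the Largest-Response Compound

The source may hold more compounds than are shown below. What is called first, only, known or untested is meant among the compounds shown, and "the series" means these compounds.

Compounds measured so far:
compound 1 `CC#CC(CC(=O)O)c1ccc(OCC2COc3ccc(Cl)cc3O2)cc1`, 104%
compound 2 `Cn1cncc1C(CC(=O)O)c1ccc(OCC2COc3ccc(Cl)cc3O2)cc1`, 62%
compound 3 `O=C(O)CC(c1ccncc1)c1ccc(OCC2COc3ccc(Cl)cc3O2)cc1`, 62%

In a functional assay on HEK293 cells for agonist activity at Free fatty acid receptor 1 (Homo sapiens), read by fluorescence and calcium flux, with a stated time of 10 min (on this read-out lower numbers stand for smaller maximal responses and higher numbers for larger maximal responses), compound 1 gives the highest of the three numbers. Its nearest neighbour is compound 2, at a number 42 percentage points lower from compound 1 to compound 2 (beyond the scatter), and its furthest is compound 3, at a number 42 percentage points lower from compound 1 to compound 3 (beyond the scatter); between those two there is no change at the digits printed from compound 2 to compound 3 (within the scatter). Compound 4 `CC#C[C@H](CC(=O)O)c1ccc(OC[C@H]2COc3ccc(Cl)cc3O2)cc1` is built from compound 1 without any change in atoms or bonds: the two compounds have the same atoms and bonds; at least one stereo element is drawn with a configuration in one of them and without one in the other: 2 of 2 stereo elements differ; a stereocentre at a saturated chain carbon is drawn without a configuration in compound 1 and R in compound 4; a stereocentre at a saturated ring carbon is drawn without a configuration in compound 1 and S in compound 4. Within the data shown here, none of the measured steps concerns a stereo element; each of them exchanges one group on the saturated chain carbon for another, and all three measured compounds carry the same pair of undefined centres. Those steps therefore give no direct measure of what defining both centres does to the maximal response. As compound 1 already reaches 104%, a single stereoisomer is expected to sit near it, and the estimated step is a number 4 percentage points lower from compound 1 to compound 4 (within the scatter), within the scatter. Compound 4 is thus expected to give 100%, with a range from 75% to 118%.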

Compound 4, largest response reached (Emax), in percent of the reference or control that the assay uses: 47%
The estimate for compound 4 lay 53 percentage points above the measured number, and the stated range ends above it.
By their numbers in this assay, from the lowest: compound 4; then compounds 2 and 3 (each within the scatter of the next); then compound 1.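

In this assay, fixing the saturated chain carbon as R and the saturated ring carbon as S, with every atom and bond kept, gives a number 57 percentage points lower from compound 1 to compound 4 (beyond the scatter). Among these compounds, the earlier compounds differed only in the group on the saturated chain carbon, so this is the first sign that the maximal response also depends on how these stereocentres are drawn, even with the prop-1-yn-1-yl group retained. The only structural difference available to account for the step is this one: the fact that one of compounds 1 and 4 is drawn with a defined configuration and the other without, at the place where they differ

The compounds shown leave open which of the two centres carries the change and what the other combinations of configuration would give. They also leave open whether a cyclopropyl group on the saturated chain carbon would show the same dependence on configuration.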